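This account rests on a few compounds, and the source may have more. Where it says the series, first, only, none or still open, it means among the compounds named here.

Working notes on the series. Compound 1 `O=C(O)C[C@H](O)C[C@H](O)CCn1c(C(F)(F)F)nc(-c2ccc(F)cc2)c1-c1ccc(C(F)(F)F)cc1` and compound 2 `Cc1cc(C)cc(-c2c(-c3ccc(F)cc3)nc(C(F)(F)F)n2CC[C@@H](O)C[C@@H](O)CC(=O)O)c1` share one core and differ only in the aryl group on an aromatic carbon of the core. In an assay on microsomes from liver for inhibition of 3-hydroxy-3-methylglutaryl-coenzyme A reductase (Rattus norvegicus) (on this read-out lower numbers stand for stronger inhibition and higher numbers for weaker inhibition), compound 1 gives > 1000 nM, which is a limit of the assay rather than a number. Among the measured compounds shown here, in the same this assay compound 2 gives 38 nM, the only actual number in the set so far. The other entry is the limit noted for compound 1 (the limit of > 1000 nM in this assay, at which 1 of the 2 values shown sits). For the measured compounds named here, the one measured step sits at the very position now under change: an at least 26-fold lower number from compound 1 to compound 2 (1.42 log units; beyond the scatter), a large step, so this aryl position clearly matters for inhibition.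

Compound 3 `O=C(O)C[C@H](O)C[C@H](O)CCn1c(C(F)(F)F)nc(-c2ccc(F)cc2)c1-c1cccs1` is not yet measured. It differs from compound 2 by thiophen-2-yl in place of 3,5-dimethylphenyl on an aromatic carbon. Going by the values given here, no measured step covers a five-membered heteroaryl here; the only guide is that the position is sensitive, as the step from compound 1 shows. A change of moderate size is therefore expected, more likely toward a higher number than a lower one, but with wide uncertainty, estimated as a 3.2-fold higher number from compound 2 to compound 3 (0.50 log units; beyond the scatter). For compound 3 the estimate in this assay is 120 nM, with a range from 30 nM to 500 nM.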

Compound 3, half-maximal inhibitory concentration: 215 nM
Estimate against measurement, compound 3: 1.8-fold (0.25 log units) below; the range from low to high includes it.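

In this assay, thiophen-2-yl keeps a measurable inhibition at this position but does not match 3,5-dimethylphenyl, with a 5.7-fold higher number from compound 2 to compound 3 (0.75 log units; beyond the scatter). The same group compares better with 4-(trifluoromethyl)phenyl, with an at least 4.6-fold lower number from compound 1 to compound 3 (0.66 log units; beyond the scatter), so the two six-membered aryl groups fall on either side of the five-membered one, and ring size alone does not order these three compounds, among which compound 2 gives the lowest number. The true size of that second step stays unknown, since the value of compound 1 is a limit of the assay and not a number: the limit of > 1000 nM in this assay, at which 1 of the 3 values shown sits.

The compounds shown leave open where an unsubstituted phenyl or a 3-methylphenyl would fall, and so how much of the standing of compound 2 belongs to its two methyl groups. On these data alone, it also remains open whether thiophen-3-yl, furan-2-yl or a pyridine ring at this position would follow thiophen-2-yl, and whether the order of these aryl groups would hold with another group in place of the 4-fluorophenyl group.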